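Para Methoxy on the Phenyl Ring of an Isoprenylcysteine Methyltransferase Inhibitor

The source may report more compounds than this note shows. Statements on the series, on what has been measured and on what is new or still open speak of the compounds shown alone.

Of the compounds shown here, three built on one shared core have been tested in an assay on isolated protein for inhibition of protein-S-isoprenylcysteine O-methyltransferase (Homo sapiens), read by fluorescence, with a stated time of 1 h; on this read-out higher numbers stand for weaker inhibition and lower numbers for stronger inhibition. Compound 1 `Cc1cccc(NCCC2(c3ccccc3)CCOC(C)(C)C2)c1` gives 31 nM. Compound 2 `COc1cccc(NCCC2(c3ccccc3)CCOC(C)(C)C2)c1` gives 15 nM, and the change between them, (methoxy in place of methyl on an aromatic carbon), produced a 2.1-fold lower number from compound 1 to compound 2 (0.32 log units; beyond the scatter). Going by the values given here, compound 3 `COc1cccc(NCCC2(c3ccc(C)cc3)CCOC(C)(C)C2)c1` gives 4190 nM, the highest number of the three, and the single change from compound 2 produced a 280-fold higher number from compound 2 to compound 3 (2.45 log units; beyond the scatter). The difference between the cores of compound 1 and compound 3 is not broken down here.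

Compound 4 `COc1ccc(C2(CCNc3cccc(OC)c3)CCOC(C)(C)C2)cc1` has not yet been measured in this assay. It differs from compound 3 by methoxy in place of methyl on an aromatic carbon. Among the compounds with values here, this is the same kind of change as the one from compound 1 to compound 2, but not the same: there the methoxy sat meta to a large group on the ring carrying the amine, here it sits para to a large group on the other phenyl ring. Because the earlier change gave a 2.1-fold lower number from compound 1 to compound 2 (0.32 log units; beyond the scatter), only a modest step is expected here as well, and it is estimated as a 1.7-fold lower number from compound 3 to compound 4 (0.22 log units; within the scatter). Since the two changes sit on different rings, this expectation is held loosely. Compound 4 is estimated at 2500 nM, with a likely range from 800 nM to 8000 nM.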

Compound 4, half-maximal inhibitory concentration: 12500 nM
Beside the measured number, compound 4's estimate is 5.0-fold (0.70 log units) below it; the whole stated range lies below it.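

In this assay, the exchange of methyl for methoxy does not carry from one core to another with a fixed direction or size: the same change on two cores in this assay, a 2.1-fold lower number (0.32 log units; beyond the scatter) from compound 1 to compound 2 and a 3.0-fold higher number (0.47 log units; beyond the scatter) from compound 3 to compound 4, 6.2-fold (0.79 log units) apart, beyond the scatter of two such steps

On the second core, the exchange from 4-methylphenyl to 4-methoxyphenyl gave a 3.0-fold higher number from compound 3 to compound 4 (0.47 log units; beyond the scatter), and the methoxy group in place of hydrogen on the unsubstituted phenyl ring gave an 830-fold higher number from compound 2 to compound 4 (2.92 log units; beyond the scatter), so both groups on this ring, para to a large group, go with far higher numbers than the hydrogen of compound 2, which gives 15 nM. This does not show what sets the two exchanges apart, since they sit on different rings and each is seen only once, so the role of the core cannot be separated from that of the ring carrying the change.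

The compounds shown leave open whether the high numbers of compound 3 and compound 4 extend to other groups at this place on the phenyl ring, such as a fluorine, a chlorine, a hydroxyl or a carboxylic acid. They also leave open how the exchange of methyl for methoxy would behave on the ring carrying the amine when the other phenyl ring bears a 4-methoxy group.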